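Cytotoxicity of a quinazolinone series: replacing a pyridyl with fluorophenyl

A few compounds are considered here, and "the series" means these few. Any claim that something is new, unique, unknown or untested is made for them only; others in the source may bear on it.

The account follows three measured compounds in an ADME assay on L6 cells (Rattus norvegicus) for cytotoxicity, read by fluorescence and resazurin assay, with a stated time of 72 h (a higher number here means that more compound is needed for the effect, a lower number that less compound is needed), and one that awaits measurement there. Compound 1 `Cc1ccncc1-c1ccc2[nH]c(=O)nc(-c3ccccc3)c2c1` carries a 4-methylpyridin-3-yl group on the shared core. In this assay compound 1 gives only a limit, > 50000 nM, which is the limit of > 50000 nM in this assay, at which 1 of the 3 values shown sits. Compound 2 `CN(C)c1ccc(-c2ccc3[nH]c(=O)nc(-c4ccccc4)c3c2)cn1` gives 50000 nM in this assay. Compound 3 `O=c1nc(-c2ccccc2)c2cc(-c3cnc4ccccc4c3)ccc2[nH]1` is also reported only as a limit in this assay, > 16000 nM, which is the limit of > 16000 nM in this assay, at which 1 of the 3 values shown sits. Compound 1 thus stands at a limit rather than a number, and one of the other two values is a limit as well, so no ordering among the three can be drawn.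

Compound 4 `O=c1nc(-c2ccccc2)c2cc(-c3cccc(F)c3)ccc2[nH]1` differs from compound 1 by 3-fluorophenyl in place of 4-methylpyridin-3-yl on an aromatic carbon. For the measured compounds named here, no step between measured compounds isolates this change. Given that all three measured values sit at or near the same high region, no step beyond the usual scatter is expected in this assay in either direction. Compound 4 is therefore estimated at 45000 nM, with a range from 15000 nM to 120000 nM. That estimate corresponds to an expected at least 1.1-fold lower number from compound 1 to compound 4 (0.04 log units; that floor lies within the scatter), within the scatter.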

Compound 4, half-maximal effective concentration: 23000 nM
Compound 4: middle estimate off by 2.0-fold (0.29 log units), on the high side; low and high end bracket the measured number.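

Replacing 4-methylpyridin-3-yl with 3-fluorophenyl on an aromatic carbon gives the only step among the compounds shown that isolates one change, and it shows that this position can move the read-out in this assay: the change gives an at least 2.1-fold lower number from compound 1 to compound 4 (0.33 log units; beyond the scatter). The new ring of carbon only thus brings the value in this assay down from the limit of compound 1 to a measured number. That step is a floor and not an exact size because compound 1 stands at a limit: the limit of > 50000 nM in this assay, at which 1 of the 4 values shown sits.

For the compounds shown here, the swap removes the ring nitrogen and the methyl group and adds fluorine all at once, so the single step does not show which of these matters. Going by these compounds, how a plain phenyl or a carboxylic acid on that ring would read remains open.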